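Urea aryl swap on a triazole-pyridine ether scaffold

The compounds below may be only part of what the source reports. "The series", "measured", "known", "first", "only" and "open" are said of these compounds alone.

Measured compounds and their values:
compound 1 `CCN(CC)CCn1cnnc1-c1cc(Oc2ccc(NC(=O)Nc3ccc(Cl)cc3Cl)cc2F)ccn1`: 1790 nM
compound 2 `CN(C)CCCn1cnnc1-c1cc(Oc2ccc(NC(=O)Nc3ccc(Cl)c(C(F)(F)F)c3)cc2F)ccn1`: 7880 nM
compound 3 `CN(C)CCCn1cnnc1-c1cc(Oc2ccc(NC(=O)Nc3ccc(F)c(Cl)c3)cc2F)ccn1`: 14200 nM

In a functional assay on MDA-MB-231 cells (Homo sapiens) for antiproliferative activity, read by MTT assay, with a stated time of 72 h (a higher number here means a weaker inhibitor, a lower number a stronger inhibitor), compound 3 gives the highest number of the three measured compounds. Its nearest neighbour is compound 2, and the step of a 1.8-fold higher number from compound 2 to compound 3 (0.26 log units; within the scatter) lies within the scatter. Compound 1 stands furthest away with the lowest number of the three, beyond the scatter from compound 3; compound 1 also carries a different amine side chain, so its two values with compound 3 cannot be read as a single change.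

Compound 4 `CN(C)CCCn1cnnc1-c1cc(Oc2ccc(NC(=O)Nc3ccc(Cl)cc3Cl)cc2F)ccn1` differs from compound 3 in one place: 2,4-dichlorophenyl in place of 3-chloro-4-fluorophenyl on an amide-type nitrogen. Going by the values given here, no measured step covers exactly this change. Among the compounds with values here, the only measured step on the urea aryl group, from compound 2 to compound 3, was within the scatter. Compound 1 carries the same 2,4-dichlorophenyl group that enters in compound 4, and compound 1 gives 1790 nM where compound 3 gives 14200 nM. Compound 1 also differs from compound 3 in its amine side chain, so these two values do not show the aryl swap on its own. The account therefore expects a modest move to a lower number in this assay, estimated as a 4.1-fold lower number from compound 3 to compound 4 (0.61 log units; beyond the scatter). Compound 4 is estimated at 3500 nM, with a range from 1200 nM to 10000 nM.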

Compound 4, half-maximal inhibitory concentration: 7490 nM
For compound 4 the middle estimate is 2.1-fold (0.33 log units) below the measured one; low and high end bracket the measured number.
By their numbers in this assay, from the lowest: compound 1; then compounds 4, 2 and 3 (each within the scatter of the next).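

In this assay, 2,4-dichlorophenyl on the amide-type nitrogen gives a 1.9-fold lower number from compound 3 to compound 4 (0.28 log units; within the scatter) and a 1.1-fold lower number from compound 2 to compound 4 (0.02 log units; within the scatter), so with a 1.8-fold higher number from compound 2 to compound 3 (0.26 log units; within the scatter) as well, the three aryl groups on this dimethylamino side chain all lie within the scatter of one another. With 2,4-dichlorophenyl held in place, the side chain alone gives a 4.2-fold higher number from compound 1 to compound 4 (0.62 log units; beyond the scatter), the only single change among these compounds that lies beyond the scatter, and so the amine end, not the aryl group, is where this small set shows a clear difference. No measurement shown here gives a reason for either result.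

The compounds shown leave open whether the side chain step holds with 3-chloro-4-fluorophenyl or 4-chloro-3-(trifluoromethyl)phenyl on the amide-type nitrogen, since only the 2,4-dichlorophenyl pair allows this comparison. They also leave open how a morpholine, a carboxylic acid or a longer chain in place of the diethylamino end would read in this assay.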